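This account rests on a few compounds, and the source may have more. Where it says the series, first, only, none or still open, it means among the compounds named here.

Measured compounds:
Compound 1, `CC(C)[C@H](NC(=O)COc1cccc2ccccc12)C(=O)N[C@@H](CC(=O)O)C(=O)COc1cccc2ccccc12` — in a functional assay on Jurkat cells (Homo sapiens) (a lower number here means a stronger inhibitor, a higher number a weaker inhibitor), compound 1 gives > 100000 nM, a limit of the assay.
Compound 2, `CC(C)[C@H](NC(=O)COc1cccc2ccccc12)C(=O)N[C@@H](CC(=O)O)C(=O)COc1ccccc1C(F)(F)F` — in this assay compound 2 gives > 100000 nM, also a limit of the assay.
Compound 3, `CC(C)[C@H](NC(=O)COc1cccc2ccccc12)C(=O)N[C@@H](CC(=O)O)C(=O)COc1ccc(C(F)(F)F)cc1` — in this assay compound 3 gives > 100000 nM, again a limit of the assay.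

Compound 3 thus stands only at a limit, as do the two other values; no number is known for any of the three. The three steps among them are unreadable for the same reason: a step that the two limits leave unreadable from compound 1 to compound 2, a step that the two limits leave unreadable from compound 1 to compound 3 and a step that the two limits leave unreadable from compound 2 to compound 3. The whole picture rests on a single point, (the limit of > 100000 nM in this assay, at which 3 of the 3 values shown sit).

Compound 4, `CC(C)[C@H](NC(=O)COc1cccc2ccccc12)C(=O)N[C@@H](CC(=O)O)C(=O)COc1ccc(Oc2ccccc2)cc1`, is yet to be measured in this assay. It differs from compound 3 in one place: phenoxy in place of trifluoromethyl on an aromatic carbon. Going by the values given here, the two measured steps that swap the aryl group on the oxygen on a saturated carbon are the nearest in kind, but both are unreadable, so no size can be borrowed from them, and no measured step touches an aromatic carbon at all. The expectation is therefore that compound 4 stays at the limit, with the step from compound 3 estimated as a step that the limit leaves unreadable from compound 3 to compound 4. Compound 4 in this assay is expected around 150000 nM, between 30000 nM and 1000000 nM, most likely reported only as a limit.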

Compound 4, half-maximal inhibitory concentration: 12700 nM
Estimate against measurement, compound 4: 12-fold (1.07 log units) above, outside the stated range (below it).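

In this assay, phenoxy in place of trifluoromethyl on the aromatic carbon, para to a large group, gives an at least 7.8-fold lower number from compound 3 to compound 4 (0.89 log units; beyond the scatter). This aromatic carbon is therefore a place where a change in the shared core can be read, whereas the aryl swaps among compound 1, compound 2 and compound 3 cannot be read at all. Compound 4, at 12700 nM, is the only compound shown with a number rather than a limit, and it gives the series its first value to compare against, the rest resting on a single point: the limit of > 100000 nM in this assay, at which 3 of the 4 values shown sit.

With one pair, the entering phenoxy differs from trifluoromethyl at once in its aromatic ring, its oxygen and its count of 7 heavy atoms against 4, and these cannot be told apart, nor can the true size of the step be given. On these data alone, whether phenyl joined directly to the ring, benzyl, methoxy or an amine on the same aromatic carbon would also leave the limit stays open, as does whether phenoxy would do the same on another carbon of that ring.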